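The compounds below may be only part of what the source reports. "The series", "measured", "known", "first", "only" and "open" are said of these compounds alone.

Measured compounds:
Compound 1, `CC(C)C[C@H](N)c1cc(C(F)(F)F)ccc1N1CCN(C(=O)COc2ccc(O)cc2)CC1`: in an assay on HEK293 cells for displacement of a labelled ligand from Melanocortin receptor 4 (Homo sapiens) (on this read-out higher numbers stand for weaker inhibition and lower numbers for stronger inhibition), compound 1 gives 4600 nM
Compound 2, `CC(C)C[C@H](N)c1cc(C(F)(F)F)ccc1N1CCN(C(=O)CCC2CCCCC2)CC1`: in this assay compound 2 gives 5700 nM

Compound 2 holds the highest of the two numbers, and its nearest neighbour is compound 1, separated by a 1.2-fold higher number from compound 1 to compound 2 (0.09 log units; within the scatter). Compound 3, `CC(C)C[C@H](N)c1cc(C(F)(F)F)ccc1N1CCN(C(=O)CCC(=O)N(C)C)CC1`, arises from compound 2 by dimethylcarbamoyl in place of cyclohexyl on a saturated chain carbon, two bonds along the chain from a carbonyl carbon. Within the data shown here, the only measured step that touches this chain end, a 1.2-fold higher number from compound 1 to compound 2 (0.09 log units; within the scatter), exchanged one chain end for another and stayed within the scatter. With no other comparison available, the expected step from compound 2 to compound 3 is a 1.1-fold lower number from compound 2 to compound 3 (0.06 log units; within the scatter), no direction beyond the scatter. Compound 3 is therefore estimated at 5000 nM, expected between 1500 nM and 16000 nM.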

Compound 3, inhibition constant: > 10000 nM
Compound 3: only a limit was reported; the forecaster's own chance of this, stated with the estimate: 10%; middle value at least 2.0-fold (0.30 log units) away from the limit.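

Compound 3 gives no number in this assay, only a limit of the assay: the limit of > 10000 nM in this assay, at which 1 of the 3 values shown sits. The chain end at this position can therefore change the result, which the earlier pair did not show, with an at least 2.1-fold higher number from compound 1 to compound 3 (0.33 log units; beyond the scatter). Against the cyclohexyl end the floor is less clear, at an at least 1.7-fold higher number from compound 2 to compound 3 (0.24 log units; that floor lies within the scatter), so that step alone does not separate the two ends.

As far as these compounds go, the true value of compound 3 stays open. So does the effect of a chain ending in an amine or a carboxylic acid at this position.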